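Compound 3 to compound 4: a methyl on an aromatic carbon

This account rests on a few compounds, and the source may have more. Where it says the series, first, only, none or still open, it means among the compounds named here.

Measured so far in a functional assay on RAW264.7 cells (Mus musculus) for inhibition, read by Griess assay, with stated times of 1 h and 24 h (on this read-out higher numbers stand for weaker inhibition and lower numbers for stronger inhibition), each value a limit:
- compound 1 `COc1ccc(C(O)C2OC(=O)c3c(OC)cc(OC)cc32)cc1`: > 10000 nM
- compound 2 `CCC(C)Oc1ccc(C(O)C2OC(=O)c3c(OC)cc(OC)cc32)cc1`: > 10000 nM
- compound 3 `COc1cc(OC)c2c(c1)C(C(O)c1ccc(OCc3ccccc3)cc1)OC2=O`: > 10000 nM

Not yet measured: compound 4 `COc1cc(OC)c2c(c1)C(C(O)c1ccc(OCc3ccc(C)cc3)cc1)OC2=O`.

Compound 3 stands at > 10000 nM, which is a limit and not a number. It shares that position with the other measured compounds: the limit of > 10000 nM in this assay, at which 3 of the 3 values shown sit. No order among them can be read.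

The change is methyl in place of hydrogen on an aromatic carbon, para to a large group, turning benzyloxy into (4-methylbenzyl)oxy: methyl in place of hydrogen on an aromatic carbon.

Going by the values given here, the steps that bear on it all concern the group on the same oxygen: a step that the two limits leave unreadable from compound 1 to compound 2, a step that the two limits leave unreadable from compound 1 to compound 3 and a step that the two limits leave unreadable from compound 2 to compound 3. None has a readable size, so they give no direction and no measured effect for this change. The expected step is therefore none beyond the scatter, and the estimate is a step that the limit leaves unreadable from compound 3 to compound 4. A further limit in this assay is the likeliest result. For compound 4 the estimated value is 15000 nM, with an expected range of 5000 nM to 40000 nM.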

Compound 4, half-maximal inhibitory concentration: 3120 nM
Estimate against measurement, compound 4: 4.8-fold (0.68 log units) above; measured number outside the range, below it.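

In this assay, going by these compounds alone, methyl in place of hydrogen on the benzyloxy ring gives a readable change, an at least 3.2-fold lower number from compound 3 to compound 4 (0.50 log units; beyond the scatter), whereas the earlier steps on this oxygen cannot be read. On these data alone, two further steps end at the same compound, an at least 3.2-fold lower number from compound 2 to compound 4 (0.50 log units; beyond the scatter) and an at least 3.2-fold lower number from compound 1 to compound 4 (0.50 log units; beyond the scatter), and all three start from a limit, so their true sizes stay unknown. This aromatic carbon is therefore the only place shown where a single change moves a compound off the shared limit: the limit of > 10000 nM in this assay, at which 3 of the 4 values shown sit.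

Whether this effect is specific to methyl stays open, since no chloro, methoxy or amine at this carbon is among the compounds shown. As far as these compounds go, it also stays open whether an ethyl, a longer chain or a carboxylic acid there would give a lower number than compound 4 does.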